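The source may hold more compounds than are shown below. What is called first, only, known or untested is meant among the compounds shown, and "the series" means these compounds.

Measured so far:
compound 1, `COc1ccc(Nc2nc3ccccc3nc2S(=O)(=O)c2ccccc2)cc1`: 11900 nM
compound 2, `COc1ccc(Nc2nc3ccccc3nc2S(=O)(=O)c2ccc(C)cc2)cc1`: a limit of the assay, > 50000 nM
compound 3, `COc1ccc(S(=O)(=O)c2nc3ccccc3nc2Nc2ccccc2)cc1`: 13200 nM

In a functional assay on A549 cells (Homo sapiens) for cytotoxicity, read by MTT assay, with a stated time of 72 h (a lower number here means a stronger inhibitor, a higher number a weaker inhibitor), compound 3 gives 13200 nM, the highest of the two plain numbers. Compound 1 gives 11900 nM, a gap to compound 3 that lies within the usual scatter. Compound 2 sits at the limit of > 50000 nM in this assay, at which 1 of the 3 values shown sits, so no number is known for it.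

Compound 4, `COc1ccc(Nc2nc3ccccc3nc2S(=O)(=O)c2ccc(OC)cc2)cc1`, is not yet measured. It differs from compound 3 by methoxy in place of hydrogen on an aromatic carbon. Within the data shown here, one measured step touches a related change, though on the other aromatic ring: an at least 4.2-fold higher number from compound 1 to compound 2 (0.62 log units; beyond the scatter), where a small group was added on an aromatic carbon. As far as these compounds go, that step reached a limit, so its full size is unknown, but it points toward a weaker inhibitor. For compound 4 the expected outcome is therefore a higher number in this assay, with an estimated step of a 2.3-fold higher number from compound 3 to compound 4 (0.36 log units; beyond the scatter). The estimate for compound 4 is 30000 nM, in a range from 10000 nM to 100000 nM.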

Compound 4, half-maximal inhibitory concentration: 8260 nM
For compound 4 the middle estimate is 3.6-fold (0.56 log units) above the measured one, and the stated range ends above it.
By their numbers in this assay, from the lowest: compounds 4, 1 and 3 (each within the scatter of the next). At a limit, above all of these: compound 2.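

In this assay, going from anilino to (4-methoxyphenyl)amino gives a 1.6-fold lower number from compound 3 to compound 4 (0.20 log units; within the scatter), and going from phenyl to 4-methoxyphenyl on the sulfone gives a 1.4-fold lower number from compound 1 to compound 4 (0.16 log units; within the scatter), so methoxy on either ring leaves the number within the scatter. On the sulfone's ring, methyl and methoxy at the same place read differently: the change from one to the other gives an at least 6.0-fold lower number from compound 2 to compound 4 (0.78 log units; beyond the scatter), so the weakening in an at least 4.2-fold higher number from compound 1 to compound 2 (0.62 log units; beyond the scatter) does not extend to methoxy. Compound 2 has a limit and not a number, so the full size of both steps that involve it stays unknown: the limit of > 50000 nM in this assay, at which 1 of the 4 values shown sits.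

The compounds shown leave open how a hydroxyl, a fluorine or an amine would read at this place on the sulfone's ring. They also leave open how a longer chain in place of methoxy would read on either ring.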